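The source may report more compounds than this note shows. Statements on the series, on what has been measured and on what is new or still open speak of the compounds shown alone.

Measured in a physicochemical assay for solubility, read by nephelometry; a lower number here means a less soluble compound, a higher number a more soluble compound:
- compound 1 `CC1(C)C(=O)N(c2ccc(SC(F)(F)F)cc2)C(=O)N1Cc1ccncc1` gives < 0.02 ug/mL
- compound 2 `CN(C)c1cc(CN2C(=O)N(c3ccc(SC(F)(F)F)cc3)C(=O)C2(C)C)ccn1` gives < 0.022 ug/mL
- compound 3 `CC1(C)C(=O)N(c2ccc(SC(F)(F)F)cc2)C(=O)N1Cc1ccnc(Nc2ccccc2)c1` gives < 0.025 ug/mL

Each of these entries is a limit of the assay and not a number.

Compound 3 therefore has no exact position, and < 0.025 ug/mL is only its limit. The next compound, compound 4 `CNc1cc(CN2C(=O)N(c3ccc(SC(F)(F)F)cc3)C(=O)C2(C)C)ccn1`, has not yet been measured. The change is anilino to methylamino, with methyl in place of phenyl on a nitrogen on an aromatic ring.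

The closest measured change is a step that the two limits leave unreadable from compound 2 to compound 3, which also swaps the group on that aromatic carbon. The other two, a step that the two limits leave unreadable from compound 1 to compound 2 and a step that the two limits leave unreadable from compound 1 to compound 3, give no measurable size either. With no readable step to build on, no step beyond the scatter can be forecast in either direction.

Compound 2, the closest relative, also gave only a limit, < 0.022 ug/mL in this assay. The expected step is a step that the limit leaves unreadable from compound 3 to compound 4 and a limit is the most likely report. For compound 4 the estimated value is 0.022 ug/mL within an expected range of 0.012 ug/mL to 0.06 ug/mL in this assay here.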

Compound 4, solubility: 0.075 ug/mL
Beside the measured number, compound 4's estimate is 3.4-fold (0.53 log units) below it; the whole stated range lies below it.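

In this assay, compound 4 gives the only readable number among the compounds shown, so the steps among compounds 1, 2 and 3 cannot be read, while this position now yields a step with a lower bound: an at least 3.0-fold higher number from compound 3 to compound 4 (0.47 log units; beyond the scatter), with methyl in place of phenyl on the nitrogen. Two more such steps follow: an at least 3.4-fold higher number from compound 2 to compound 4 (0.53 log units; beyond the scatter), with hydrogen in place of methyl on that nitrogen, and an at least 3.7-fold higher number from compound 1 to compound 4 (0.57 log units; beyond the scatter), with methylamino in place of hydrogen on the aromatic carbon. The true size of the step from compound 3 stays unknown because compound 3 stands at a limit of the assay: the limit of < 0.025 ug/mL in this assay, at which 1 of the 4 values shown sits.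

From the compounds shown here alone, whether an ethyl or a cyclopropyl on that nitrogen would also give a readable number remains open. With a single readable value, no trend across the groups on that nitrogen can be drawn.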